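This account rests on a few compounds, and the source may have more. Where it says the series, first, only, none or still open, it means among the compounds named here.

Measured in an ADME assay on HeLa cells (Homo sapiens) for cytotoxicity; on this read-out lower numbers stand for higher toxicity in this test and higher numbers for lower toxicity in this test:
- compound 1 `CCN(CC)CN1C(=O)/C(=N/NC(=S)Nc2ccccc2)c2cc(Cl)ccc21`: 13500 nM
- compound 2 `CCN(CC)CN1C(=O)/C(=N/NC(N)=S)c2cc(Cl)ccc21`: > 100000 nM (a limit)
- compound 3 `CCN(CC)CN1C(=O)/C(=N/NC(=S)Nc2ccc(OC)cc2)c2ccccc21`: > 100000 nM (a limit)

Compound 3 stands at a limit of the assay and has no number. Compound 4 `CCN(CC)CN1C(=O)/C(=N/NC(=S)Nc2ccc(OC)cc2)c2cc(Cl)ccc21` differs from it by chloro in place of hydrogen on an aromatic carbon. Going by the values given here, no measured step isolates this change. The only one, an at least 7.4-fold higher number from compound 1 to compound 2 (0.86 log units; beyond the scatter), concerns a different place and bears on it indirectly. Among the compounds with values here, compound 1, at 13500 nM, is the only compound with a number, and it carries both the chloro and a phenyl ring on the nitrogen, as compound 4 does. A move to a lower number in this assay is therefore expected, of similar size to that step but uncertain. The expected change is an at least 3.3-fold lower number from compound 3 to compound 4 (0.52 log units; beyond the scatter). For compound 4 the estimated value is 30000 nM, with an expected range of 10000 nM to 100000 nM.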

Compound 4, half-maximal cytotoxic concentration: 13200 nM
Compound 4: middle estimate off by 2.3-fold (0.36 log units), on the high side; measured number inside the range.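

In this assay the chloro on the aromatic carbon of the fused system now has a step of its own, with the 4-methoxyphenyl group held constant (an at least 7.5-fold lower number from compound 3 to compound 4 (0.87 log units; beyond the scatter)). The 4-methoxyphenyl group on the amide-type nitrogen counts as the phenyl did in the chloro series (an at least 7.5-fold lower number from compound 2 to compound 4 (0.87 log units; beyond the scatter)), while methoxy in place of hydrogen on that phenyl ring makes no difference beyond the scatter (a 1.0-fold lower number from compound 1 to compound 4 (0.01 log units; within the scatter)).

From the compounds shown here alone, whether bromo in place of chloro, or an amine or a carboxylic acid in place of methoxy, gives the same reading remains open. The full size of the first two steps also remains open because compound 2 and compound 3 are limits and not numbers: the limit of > 100000 nM in this assay, at which 2 of the 4 values shown sit.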